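Swapping Bromo for Chloro on the Shared Core

A few compounds are considered here, and "the series" means these few. Any claim that something is new, unique, unknown or untested is made for them only; others in the source may bear on it.

Going by the values given here, compound 1 `Cc1ccc2nc(/N=C3\C(=O)N(CN4CCCCC4)c4cccc(Br)c43)sc2c1` was examined in a functional assay on MDA-MB-468 cells (Homo sapiens) for cytotoxicity, read by sulforhodamine B assay, with a stated time of 48 h (a higher number here means a weaker inhibitor of growth, a lower number a stronger inhibitor of growth), where compound 1 gives 24000 nM, the lowest of the three numbers measured so far. Compound 2 `CCN(CC)CN1C(=O)C(=O)c2c(Cl)cccc21` gives 28300 nM, a number within the usual scatter of that of compound 1, so the two cannot be ordered. Compound 3 `Cc1ccc2nc(/N=C3\C(=O)N(CN(c4ccccc4)c4ccccc4)c4cccc(Cl)c43)sc2c1` gives 85000 nM, a weaker result that lies beyond the scatter from compound 1. The untested compound 4 `Cc1ccc2nc(/N=C3\C(=O)N(CN4CCCCC4)c4cccc(Cl)c43)sc2c1` differs from compound 1 in one place: chloro in place of bromo on an aromatic carbon. The exchange sits on an aromatic carbon of a six-membered aromatic ring of carbon only, part of a fused or bridged system of two rings. Among the compounds with values here, no measured pair isolates this exchange, so the step of a 1.0-fold higher number from compound 1 to compound 4 (0.02 log units; within the scatter) is expected to stay within the scatter, in no particular direction. Compound 4 is estimated at 25000 nM, with a range from 10000 nM to 60000 nM.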

Compound 4, concentration for 50% growth inhibition: 19800 nM
Compound 4: the middle estimate sits 1.3-fold (0.10 log units) above what was measured, and the stated range covers the measured number.
By their numbers in this assay, from the lowest: compounds 4, 1 and 2 (each within the scatter of the next); then compound 3.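

Going by these compounds alone, the first measured pair to isolate this exchange gives a 1.2-fold lower number from compound 1 to compound 4 (0.08 log units; within the scatter) in this assay. On this aromatic carbon of the shared core, chloro and bromo therefore cannot be told apart by growth inhibition, with the rest of compound 1 held constant. No measurement offered here explains this result.

The compounds shown leave open whether fluoro, methoxy or an amine on this carbon would move the number beyond the scatter. They also leave open whether the same exchange would read alike alongside the diphenylamino group of compound 3.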